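A few compounds are considered here, and "the series" means these few. Any claim that something is new, unique, unknown or untested is made for them only; others in the source may bear on it.

Measured compounds:
- compound 1, `Cn1cc(-c2nc3ccccc3n2C(=O)c2cccc(Br)c2)c2ccccc21`: in a functional assay on A549 cells (Homo sapiens) for inhibition, read by MTT assay, with a stated time of 24 h (on this read-out lower numbers stand for stronger inhibition of growth and higher numbers for weaker inhibition of growth), compound 1 gives 34200 nM
- compound 2, `COc1ccc2c(c1)c(-c1nc3ccccc3n1C(=O)c1cccc(Br)c1)cn2C`: compound 2 gives 24800 nM
- compound 3, `Cn1cc(-c2nc3ccccc3n2C(=O)c2ccccc2)c2cc(Br)ccc21`: compound 3 gives 23100 nM

The three values sit close together, and none of the gaps between them is wide enough to speak of a difference. Compound 2 is obtained from compound 1 by one change, (methoxy in place of hydrogen on an aromatic carbon), and the step that goes with it is a 1.4-fold lower number from compound 1 to compound 2 (0.14 log units; within the scatter). Compound 3 has the same atoms as compound 1, joined differently; the difference between the two cores is not broken down here.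

Compound 4, `COc1ccccc1C(=O)n1c(-c2cn(C)c3ccc(Br)cc23)nc2ccccc21`, stands to compound 3 as compound 2 stands to compound 1: the change is methoxy in place of hydrogen on an aromatic carbon. Among the compounds with values here, it is the same kind of change as the one from compound 1 to compound 2, but not the same. The surroundings differ. In compound 2 the methoxy sits on an aromatic carbon of a six-membered aromatic ring of carbon only, part of a fused or bridged system of two rings, meta to a fused ring and para to a fused ring. In compound 4 it sits on an aromatic carbon of a six-membered aromatic ring of carbon only, ortho to a large group.

Within the data shown here, with only one earlier example, and that one within the scatter, the expectation for compound 4 rests on the step of a 1.4-fold lower number from compound 1 to compound 2 (0.14 log units; within the scatter), so the step from compound 3 to compound 4 is expected to be small, a 1.3-fold lower number from compound 3 to compound 4 (0.11 log units; within the scatter). Compound 4 is therefore estimated at 18000 nM in this assay, with a likely range from 7000 nM to 45000 nM.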

Compound 4, concentration for 50% growth inhibition: 12800 nM
Compound 4: the middle estimate sits 1.4-fold (0.15 log units) above what was measured, within the range that was stated.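

In this assay, methoxy in place of hydrogen on an aromatic carbon gives a 1.8-fold lower number from compound 3 to compound 4 (0.26 log units; within the scatter), a step that stays within the scatter, as the earlier step on the other core did. The two steps agree, so in this small set the change carries from one core to the other without any visible disagreement: the same change on two cores in this assay, a 1.4-fold lower number (0.14 log units; within the scatter) from compound 1 to compound 2 and a 1.8-fold lower number (0.26 log units; within the scatter) from compound 3 to compound 4, 1.3-fold (0.12 log units) apart, within the scatter of two such steps. This does not show that methoxy has a real effect on either core, since neither step stands clear of the scatter; nor can two such small steps separate the role of the core from that of the surroundings, as the methoxy sits in different surroundings in compound 2 and compound 4.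

The compounds shown leave open whether another group in the place the methoxy holds in compound 4, ortho to a large group, such as an amine, a hydroxyl or a longer chain like ethoxy, would give a step beyond the scatter. They also leave open whether the agreement between the two steps would hold on further cores, or in cells other than those of this one assay.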